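Shortening a side chain while adding a hydroxy group

The compounds below may be only part of what the source reports. "The series", "measured", "known", "first", "only" and "open" are said of these compounds alone.

Three compounds share one core. Compound 1 `Nc1nc(O)c2c(n1)n(C1OC(CO)[C@@H](O)[C@H]1O)c(=O)n2CC(O)CO` gives 136% in a functional assay on the whole organism (B cells) with Mus musculus as the target; on this read-out higher numbers stand for larger maximal responses and lower numbers for smaller maximal responses. Compound 2 `C=CCn1c(=O)n(CCCCCCCC)c2nc(N)nc(O)c21` gives 130% in this assay, a value within the scatter of compound 1 and well above compound 3. Compound 3 `CCOC(=O)Cn1c(=O)n(C2OC(CO)[C@@H](O)[C@H]2O)c2nc(N)nc(O)c21` gives 86% in this assay. Among the compounds with values here, the only measured single-point step is a number 50 percentage points lower from compound 1 to compound 3 (beyond the scatter), which shows that reshaping the chain on one of the two ring nitrogens can move the response a lot.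

Compound 4 `C=CCn1c(=O)n(CCCCO)c2nc(N)nc(O)c21` is compound 2 with hydroxy in place of butyl on a saturated chain carbon, four bonds along the chain from an aromatic nitrogen. Within the data shown here, no measured step changes the chain on this nitrogen, and the step from compound 1 to compound 3 concerns the other chain and a different pair of groups, so it gives only a loose hint that such edits can matter. Compound 1 and compound 2, carrying very different chains, both sit high. For compound 4 a step of a number 5 percentage points lower from compound 2 to compound 4 (within the scatter) is therefore expected, which stays within the scatter. The estimate for compound 4 is 125%, with a range from 95% to 150%.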

Compound 4, largest response reached (reported as maximal response), in percent of the reference or control that the assay uses: 12%
The estimate for compound 4 lay 113 percentage points above the measured number; measured number below the stated range.
By their numbers in this assay, from the lowest: compound 4; then compound 3; then compounds 2 and 1 (each within the scatter of the next).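

In this assay, within the data shown here, putting hydroxy in place of butyl at this place gives a number 118 percentage points lower from compound 2 to compound 4 (beyond the scatter) and is the only measured step on this chain, so the high response of compound 2 is clearly sensitive to what sits here. The edit shortens the chain and adds a hydroxy group in one move, and this single step cannot tell which of the two matters. Nothing available explains the drop.

A plain butyl chain on this nitrogen would separate the shortening from the hydroxy group, and an octyl chain ending in hydroxy would test the same question from the other side. From the compounds shown here alone, how an amine or a carboxylic acid at the end of this chain would behave also stays open.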